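Aryl swap on a shared core with no measured activity

The compounds below may be only part of what the source reports. "The series", "measured", "known", "first", "only" and "open" are said of these compounds alone.

Compound 1 `N#CC1=C(N)Oc2c(c3nc4ccccc4nc3c3ccccc23)C12C(=O)N(Cc1cnnn1-c1ccc(Cl)c(Cl)c1)c1ccccc12` gives > 50000 nM in a functional assay on HepG2 cells (Homo sapiens) for antiproliferative activity, read by MTT assay, with a stated time of 48 h (on this read-out higher numbers stand for weaker inhibition and lower numbers for stronger inhibition), which is a limit of the assay rather than a number.
Compound 2 `CCOc1ccc(-n2nncc2CN2C(=O)C3(C(C#N)=C(N)Oc4c(N)cc5nc6ccccc6nc5c43)c3ccccc32)cc1` gives > 50000 nM in this assay, again a limit rather than a number.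

Compound 2 therefore stands at the limit, as does every value shown (the limit of > 50000 nM in this assay, at which 2 of the 2 values shown sit). Within the data shown here, no step between measured compounds exists here. Compound 3 `N#CC1=C(N)Oc2c(N)cc3nc4ccccc4nc3c2C12C(=O)N(Cc1cnnn1-c1c(Cl)cc(Cl)cc1Cl)c1ccccc12` differs from compound 2 by 2,4,6-trichlorophenyl in place of 4-ethoxyphenyl on an aromatic nitrogen. With both neighbours at the limit, the step that the limit leaves unreadable from compound 2 to compound 3 is expected to show no change beyond the scatter. Compound 3 is estimated at 60000 nM, in a range from 20000 nM to 200000 nM, most likely reported again as a limit.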

Compound 3, half-maximal inhibitory concentration: 37800 nM
Compound 3: middle estimate off by 1.6-fold (0.20 log units), on the high side; measured number inside the range.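

On the aromatic nitrogen, 2,4,6-trichlorophenyl gives compound 3 an actual number in this assay, which neither earlier compound has. The change from 4-ethoxyphenyl brings an at least 1.3-fold lower number from compound 2 to compound 3 (0.12 log units; that floor lies within the scatter) and thus shows no firm gain in activity. The true size of the step cannot be read because compound 2 has only a limit: the limit of > 50000 nM in this assay, at which 2 of the 3 values shown sit. Going by these compounds, it remains open whether a phenyl ring carrying an amine or a carboxylic acid at this position would give a clearly lower number.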